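The source may report more compounds than this note shows. Statements on the series, on what has been measured and on what is new or still open speak of the compounds shown alone.

In a functional assay on LOX IMVI cells (Homo sapiens) for inhibition, read by sulforhodamine B assay, with a stated time of 48 h, tested at 10 uM (on this read-out lower numbers stand for less inhibition and higher numbers for more inhibition at the one concentration tested (going by the name of the read-out)), compound 1 `COc1ccc(-c2cn3ccnc3c(-c3ccc4ncn(C5CCCCC5)c4c3)n2)cc1` gives 69.6%, while compound 2 `O=Cc1ccc(-c2cn3ccnc3c(-c3ccc4ncn(C5CCCCC5)c4c3)n2)cc1` gives 46.9%. Among the compounds with values here, compound 2 therefore holds the lower of the two numbers known so far, and the only measured step, a number 22.7 percentage points lower from compound 1 to compound 2 (beyond the scatter), is what separates it from compound 1.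

Compound 3 `c1ccc2c(-c3cn4ccnc4c(-c4ccc5ncn(C6CCCCC6)c5c4)n3)cccc2c1` has not yet been measured in this assay. It differs from compound 2 by naphthalen-1-yl in place of 4-formylphenyl on an aromatic carbon. Within the data shown here, the one step on record, a number 22.7 percentage points lower from compound 1 to compound 2 (beyond the scatter), concerns the same place on the shared core but swaps a different pair of groups, so it bears on the move to compound 3 only loosely: it shows that the group at this place can shift the read-out by a modest amount, without telling which way a naphthalen-1-yl would take it. Among the measured compounds shown here, no measured compound carries two fused six-membered aromatic rings of carbon at this place, so the direction remains open. Compound 3 is expected to give 55%, within a range from 25% to 85%. That estimate amounts to an expected step of a number 8.1 percentage points higher from compound 2 to compound 3 (within the scatter), a shift that may not rise beyond the scatter.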

Compound 3, a percentage reported as inhibition, at one concentration (the size of the read-out at that concentration, not a potency): 7.43%
The estimate for compound 3 lay 47.6 percentage points above the measured number, outside the stated range (below it).
By their numbers in this assay, from the lowest: compound 3; then compound 2; then compound 1.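

In this assay the change to naphthalen-1-yl brings a number 39.5 percentage points lower from compound 2 to compound 3 (beyond the scatter) and a number 62.2 percentage points lower from compound 1 to compound 3 (beyond the scatter), so this place can do more than the earlier a number 22.7 percentage points lower from compound 1 to compound 2 (beyond the scatter) showed: the choice of group here can take the read-out from substantial inhibition to very little. Among these three compounds, the two groups with one six-membered aromatic ring of carbon, 4-methoxyphenyl and 4-formylphenyl, both stand well above naphthalen-1-yl with its two such rings, although they also differ from each other by a step beyond the scatter. No measurement on these compounds bears on why the number falls so far.

The three compounds cannot separate the effect of adding a second fused ring from the effect of losing the methoxy or formyl group, since no plain phenyl group appears among them for comparison. As far as these compounds go, it also remains open how this place would respond to a phenyl ring carrying an amine or a carboxylic acid, or to a longer chain in place of the aromatic group.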